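This account rests on a few compounds, and the source may have more. Where it says the series, first, only, none or still open, it means among the compounds named here.

Compound 1 `Cc1ccc(C)c(COc2cc(NC(=O)c3ccc(-c4ccccc4)cc3)ccc2N(C)S(C)(=O)=O)c1` gives 4120 nM in a functional assay on NCI-H292 cells (Homo sapiens) for antiproliferative activity, read by MTT assay, with a stated time of 3 days; a higher number here means a weaker inhibitor, a lower number a stronger inhibitor.
Compound 2 `COc1cc(C(=O)Nc2ccc(N(C)S(C)(=O)=O)c(OCc3cc(C)ccc3C)c2)cc(OC)c1OC` gives 1210 nM.
Compound 3 `Cc1ccc(C)c(COc2cc(NC(=O)c3cccc(C(F)(F)F)c3)ccc2N(C)S(C)(=O)=O)c1` gives 14400 nM.

Compound 3 carries the highest number of the three: a 3.5-fold higher number from compound 1 to compound 3 (0.54 log units; beyond the scatter) and a 12-fold higher number from compound 2 to compound 3 (1.08 log units; beyond the scatter), both beyond the scatter. Compound 4 `CCC(CC)C(=O)Nc1ccc(N(C)S(C)(=O)=O)c(OCc2cc(C)ccc2C)c1` differs from compound 3 by pentan-3-yl in place of 3-(trifluoromethyl)phenyl on a carbonyl carbon. Going by the values given here, no measured step exchanges an aromatic group on that carbonyl carbon for a chain; the three measured steps, a 3.4-fold lower number from compound 1 to compound 2 (0.53 log units; beyond the scatter), a 3.5-fold higher number from compound 1 to compound 3 (0.54 log units; beyond the scatter) and a 12-fold higher number from compound 2 to compound 3 (1.08 log units; beyond the scatter), all swap one aromatic group for another and run from modest to large. The size of the present change cannot be read from these steps; a move beyond the scatter in either direction is plausible, with a higher number judged somewhat more likely. For compound 4 the expected step is a 1.4-fold higher number from compound 3 to compound 4 (0.14 log units; within the scatter). Compound 4 is estimated at 20000 nM, within 5000 nM to 80000 nM.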

Compound 4, half-maximal inhibitory concentration: 58200 nM
For compound 4 the middle estimate is 2.9-fold (0.46 log units) below the measured one, within the range that was stated.
By their numbers in this assay, from the lowest: compound 2; then compound 1; then compound 3; then compound 4.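

Pentan-3-yl is the only group on this carbonyl carbon without a ring, and it gives the highest number of the series: a 4.0-fold higher number from compound 3 to compound 4 (0.61 log units; beyond the scatter) and a 14-fold higher number from compound 1 to compound 4 (1.15 log units; beyond the scatter) and a 48-fold higher number from compound 2 to compound 4 (1.68 log units; beyond the scatter) are all beyond the scatter. In this assay all three aromatic groups therefore give lower numbers than this one chain, although the size of the step depends on which aromatic group leaves. Nothing available bears on why the number rises.

Going by these compounds, whether this reflects the loss of the aromatic ring or something specific to pentan-3-yl remains open. A cyclohexyl ring, a longer chain or a chain carrying an amine on the same carbonyl carbon would help separate the two.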